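The source may report more compounds than this note shows. Statements on the series, on what has been measured and on what is new or still open speak of the compounds shown alone.

Among the compounds with values here, in a functional assay on NCI-H460 cells (Homo sapiens) for cytotoxicity, read by MTT assay, with a stated time of 72 h (a lower number here means a stronger inhibitor, a higher number a weaker inhibitor), compound 1 `CCCCNC1=CC(=O)C=C(C(C)(C)C)C1=O` gives 13000 nM and compound 2 `CCCCCCCCNC1=CC(=O)C=C(C(C)(C)C)C1=O` gives 21000 nM as its value, so compound 2 stands level with its only measured neighbour. Compound 3 `CC(C)(C)C1=CC(=O)C=C(NCc2ccccc2)C1=O` has phenyl in place of heptyl on a saturated chain carbon bound to an amine nitrogen. Within the data shown here, no measured compound carries phenyl, so the only guide is the step of a 1.6-fold higher number from compound 1 to compound 2 (0.21 log units; within the scatter) that came from butyl in place of hydrogen on the chain. No change beyond the scatter is therefore expected in this assay and the expected step is a 1.4-fold lower number from compound 2 to compound 3 (0.15 log units; within the scatter) at most a small one. The estimate for compound 3 is 15000 nM with an expected range from 6000 nM to 35000 nM in repeat measurements.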

Compound 3, half-maximal inhibitory concentration: 10000 nM
Beside the measured number, compound 3's estimate is 1.5-fold (0.18 log units) above it; measured number inside the range.
By their numbers in this assay, from the lowest: compounds 3, 1 and 2 (each within the scatter of the next, the first and the last beyond it).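

In this assay, phenyl in place of heptyl on a saturated chain carbon bound to an amine nitrogen gives a 2.1-fold lower number from compound 2 to compound 3 (0.32 log units; beyond the scatter), a modest step and the first here beyond the scatter. Phenyl in place of propyl gives a 1.3-fold lower number from compound 1 to compound 3 (0.11 log units; within the scatter), so a ring at this place can be told apart from the longer chain but not from the shorter one. Nothing shown explains either step.

On these data alone, whether ring or chain length drives the difference stays open. So does the effect of a methoxy group on the phenyl ring, or of an amine at the chain end.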